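From compound 3 to compound 4: sulfanyl to amino

This account rests on a few compounds, and the source may have more. Where it says the series, first, only, none or still open, it means among the compounds named here.

In an in vitro ADME assay on microsomes (Rattus norvegicus) for metabolic stability (a lower number here means that the compound disappears faster, a higher number that the compound lasts longer), compound 1 `CCc1nc(-c2ccc(Cl)cc2Cl)c(CC)nc1CC(CC)CC` gives 0.0417 h and compound 3 `CCc1nc(-c2ccc(Cl)cc2Cl)c(CC)nc1SC(C)CC` gives 0.0683 h. These two stand level, as a 1.6-fold higher number from compound 1 to compound 3 (0.21 log units; within the scatter) lies within the scatter. Compound 2 `CCCN(CCN(C)C)c1nc(CC)c(-c2ccc(Cl)cc2Cl)nc1CC` gives < 0.0167 h, which is a limit of the assay and not a number. Even so, an at least 4.0-fold higher number from compound 2 to compound 3 (0.61 log units; beyond the scatter) lies beyond the scatter, so compound 3 stands clear of compound 2.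

Compound 4 `CCc1nc(-c2ccc(Cl)cc2Cl)c(CC)nc1NC(CC)CC` carries (pentan-3-yl)amino in place of (sec-butyl)sulfanyl on an aromatic carbon, next to the ring nitrogen: (pentan-3-yl)amino in place of (sec-butyl)sulfanyl on an aromatic carbon.

Among the measured compounds shown here, the closest guide is compound 2, the only measured compound with an amino group at this carbon, and an at least 4.0-fold higher number from compound 2 to compound 3 (0.61 log units; beyond the scatter) points to a lower number for such a group. It is a loose guide, since (2-(dimethylamino)ethyl)(propyl)amino differs widely from (pentan-3-yl)amino. A small downward step is therefore expected, a 1.7-fold lower number from compound 3 to compound 4 (0.23 log units; within the scatter), and this expected step stays within the scatter. For compound 4 the estimated half-life is 0.04 h, with an expected range from 0.018 h to 0.09 h.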

Compound 4, half-life: 0.07 h
For compound 4 the middle estimate is 1.8-fold (0.24 log units) below the measured one; the measured number falls inside the stated range.
By their numbers in this assay, from the lowest: compounds 1, 3 and 4 (each within the scatter of the next). At a limit, below all of these: compound 2.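

In this assay, the sulfur-linked and nitrogen-linked groups at this position read level (a 1.0-fold higher number from compound 3 to compound 4 (0.01 log units; within the scatter)), and (pentan-3-yl)amino also reads level with the carbon-linked 2-ethylbutyl group (a 1.7-fold higher number from compound 1 to compound 4 (0.22 log units; within the scatter)). A nitrogen link at this carbon therefore does not by itself go with the low reading of compound 2, since two groups that both attach through nitrogen lie beyond the scatter of each other (an at least 4.1-fold higher number from compound 2 to compound 4 (0.62 log units; beyond the scatter)). The value of compound 2 is a limit and not a number, so this step has a floor but no known size: the limit of < 0.0167 h in this assay, at which 1 of the 4 values shown sits.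

Open, going by these compounds, is whether the low reading of compound 2 goes with the terminal dimethylamino group or with the loss of the amino hydrogen, which a dipropylamino group would help to separate. Also open, on these data alone, is whether a hydroxyl or carboxylic acid on the chain at this position would move the half-life clear of compounds 1, 3 and 4.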